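Methoxy in Place of Cyano on the Fused Ring

The compounds below may be only part of what the source reports. "The series", "measured", "known", "first", "only" and "open" are said of these compounds alone.

Compound 2 `Cc1ncccc1-c1cnc(NCc2c(F)cc(C#N)c3c2CCO3)n2cnnc12` stands lowest of the two numbers measured in an ADME assay on cells (Hepatocyte, Rattus norvegicus) for metabolic stability; on this read-out lower numbers stand for slow clearance and higher numbers for fast clearance: compound 2 gives 10 uL/min. Its nearest neighbour, compound 1 `Cc1ncccc1-c1cnc(NCc2c(F)cc(O)c3c2CCO3)n2cnnc12`, gives 50 uL/min in this assay. Among the measured compounds shown here, the one measured step joins these two compounds: a 5.0-fold lower number from compound 1 to compound 2 (0.70 log units; beyond the scatter).

Compound 3 `COc1cc(F)c(CNc2ncc(-c3cccnc3C)c3nncn23)c2c1OCC2` differs from compound 2 in one place: methoxy in place of cyano on an aromatic carbon. For the measured compounds named here, no measured pair shows methoxy in place of cyano, so the step from compound 1 to compound 2 bears on the question only indirectly, through the cyano group that enters there and leaves here. With methoxy being neither hydroxy nor cyano, the number for compound 3 is expected to sit somewhere between the values of compound 1 and compound 2, and the expected step is a 2.2-fold higher number from compound 2 to compound 3 (0.34 log units; beyond the scatter), an upward shift of modest size that could still fall within the scatter. Compound 3 is therefore estimated to give 22 uL/min in this assay, with a range from 8 uL/min to 60 uL/min.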

Compound 3, intrinsic clearance in a liver preparation (reported as CLH), per the amount of preparation that the assay uses: 4 uL/min
Compound 3: the middle estimate sits 5.5-fold (0.74 log units) above what was measured; measured number outside the range, below it.
By their numbers in this assay, from the lowest: compound 3; then compound 2; then compound 1.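

In this assay the methoxy group does not fall between the two earlier groups but goes past the nitrile: the exchange brings a 2.5-fold lower number from compound 2 to compound 3 (0.40 log units; beyond the scatter) and leaves the methoxy compound lowest of the three. Cyano and methoxy match in their counts of heavy atoms, hydrogen-bond donors and hydrogen-bond acceptors, so these counts do not separate the two groups, yet the read-out still moves beyond the scatter at this aromatic carbon. Methyl in place of hydrogen on the oxygen brings a 13-fold lower number from compound 1 to compound 3 (1.10 log units; beyond the scatter) as the largest step of the set, which shows that an oxygen on this carbon does not itself go with fast clearance, since the high number belongs to the free hydroxy alone.

From the compounds shown here alone, whether an ethoxy group, an amine or a carboxylic acid on this aromatic carbon would fall lower or higher than the methoxy group remains open, and three compounds cannot show how far the order extends. Nothing at hand gives a reason for the order of these three compounds.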